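The source may report more compounds than this note shows. Statements on the series, on what has been measured and on what is new or still open speak of the compounds shown alone.

In an assay on cells for agonist activity at vitamin D3 receptor (Homo sapiens), with a stated time of 96 h (on this read-out lower numbers stand for an effect already at smaller amounts and higher numbers for an effect only at larger amounts of compound), compound 1 `CCn1c(C(=O)NCCCN(C)C)ccc1C(CC)(CC)c1ccc(OCCC(O)(CC)CC)c(C)c1` gives 5 nM and compound 2 `CCN(CC)CCNC(=O)c1ccc(C(CC)(CC)c2ccc(OCCC(O)(CC)CC)c(C)c2)n1CC` gives 2.3 nM, the step between them being a 2.2-fold lower number from compound 1 to compound 2 (0.34 log units; beyond the scatter). Compound 3 `CCn1c(C(=O)Nc2ccc(OC(F)(F)F)cc2)ccc1C(CC)(CC)c1ccc(OCCC(O)(CC)CC)c(C)c1` gives > 10000 nM, which is a limit of this assay and not a number (the limit of > 10000 nM in this assay, at which 1 of the 3 values shown sits). Compound 3 therefore stands at the top of the numbers shown, with steps of an at least 2000-fold higher number from compound 1 to compound 3 (3.30 log units; beyond the scatter) and an at least 4300-fold higher number from compound 2 to compound 3 (3.63 log units; beyond the scatter). Compound 4 `CCOC(=O)C(CC(=O)OC)NC(=O)c1ccc(C(CC)(CC)c2ccc(OCCC(O)(CC)CC)c(C)c2)n1CC` differs from compound 3 by a group of 11 heavy atoms (7 carbon, 4 oxygen; no ring) in place of a group of 11 heavy atoms (7 carbon, 1 oxygen, 3 fluorine; one six-membered aromatic ring of carbon only), on an amide-type nitrogen. This entering chain is neither the 3-(dimethylamino)propyl of compound 1 nor the 2-(diethylamino)ethyl of compound 2, so the measured steps leave its place uncertain. Compound 4 is expected to move back from the limit by an at least 6.6-fold lower number from compound 3 to compound 4 (0.82 log units; beyond the scatter). The estimate for compound 4 is 1500 nM, expected between 100 nM and 10000 nM.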

Compound 4, half-maximal effective concentration: 21 nM
Compound 4: the middle estimate sits 71-fold (1.85 log units) above what was measured; measured number outside the range, below it.
By their numbers in this assay, from the lowest: compound 2; then compound 1; then compound 4. At a limit, above all of these: compound 3.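

Going by these compounds alone, on the amide-type nitrogen, the earlier compounds paired low numbers only with chains carrying an amine, yet a chain of carbon and oxygen with no ring gives only a modest rise, with a 4.2-fold higher number from compound 1 to compound 4 (0.62 log units; beyond the scatter) and a 9.1-fold higher number from compound 2 to compound 4 (0.96 log units; beyond the scatter). Against the 4-(trifluoromethoxy)phenyl group the same chain gives an at least 470-fold lower number from compound 3 to compound 4 (2.67 log units; beyond the scatter). The value of compound 3 is a limit and not a number, so that step is only a bound: the limit of > 10000 nM in this assay, at which 1 of the 4 values shown sits.

The compounds shown leave open whether a plain phenyl or a benzyl group on this nitrogen would also give a high number. They also leave open whether the carboxylic acids corresponding to the two esters of compound 4 would hold its value.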